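The compounds below may be only part of what the source reports. "The series", "measured", "known", "first", "only" and "open" are said of these compounds alone.

Values in a functional assay (aorta) with Rattus norvegicus as the target (a lower number here means a less potent compound, a higher number a more potent compound, by a factor of ten per unit of this negative logarithm), for the measured members of the series:
compound 1 `CC1(C)C=C(n2ccccc2=O)c2cc(C(=O)c3ccc([N+](=O)[O-])cc3)ccc2O1`: 6.2
compound 2 `CC1(C)C=C(n2ccccc2=O)c2cc(C(=O)c3ccccc3F)ccc2O1`: 7.08
compound 3 `CC1(C)C=C(n2ccccc2=O)c2cc(C(=O)c3ccccc3C(F)(F)F)ccc2O1`: 6.76

Compound 2 stands highest of the three numbers: a number 0.32 log units lower from compound 2 to compound 3 (beyond the scatter) and a number 0.88 log units higher from compound 1 to compound 2 (beyond the scatter), both beyond the scatter. Compound 4 `CC1(C)C=C(n2ccccc2=O)c2cc(C(=N)S)ccc2O1` is the next candidate; relative to compound 2 the change is a group of 3 heavy atoms (1 carbon, 1 nitrogen, 1 sulfur; no ring) in place of a group of 9 heavy atoms (7 carbon, 1 oxygen, 1 fluorine; one six-membered aromatic ring of carbon only), on an aromatic carbon.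

The measured steps all vary only the ring attached to the carbonyl: a number 0.88 log units higher from compound 1 to compound 2 (beyond the scatter), a number 0.56 log units higher from compound 1 to compound 3 (beyond the scatter), a number 0.32 log units lower from compound 2 to compound 3 (beyond the scatter). None removes that ring or the carbonyl, so they bear on the present step only indirectly, showing that this part of the molecule does shift the read-out. Removing it entirely is a far larger change than any measured one, so a drop is expected: a number 1.08 log units lower from compound 2 to compound 4 (beyond the scatter). Compound 4 is estimated at 6, within 5 to 7.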

Compound 4, logarithm of the reciprocal of the active concentration, log(1/C): 6.21
Compound 4: middle estimate off by 0.21 log units, on the low side, and the stated range covers the measured number.
By their numbers in this assay, from the lowest: compounds 1 and 4 (each within the scatter of the next); then compound 3; then compound 2.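

In this assay, replacing the whole (2-fluorophenyl)carbonyl group gives a modest loss, not a collapse: a number 0.87 log units lower from compound 2 to compound 4 (beyond the scatter). The aryl carbonyl is therefore not essential for a clear response at this aromatic carbon, and compound 4 at 6.21 lies within the scatter of compound 1 at 6.2. No supporting data explain this step.

From the compounds shown here alone, it remains open whether the ring or the carbonyl of compound 2 accounts for the difference. An amine, a nitrile or a carboxylic acid on this carbon could help separate these contributions.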